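The compounds below may be only part of what the source reports. "The series", "measured", "known", "first", "only" and "open" are said of these compounds alone.

Series notes. Compound 1 `CNc1nncc2c(C)ncn12` is the reference point for the step that follows. In a functional assay for inhibition, with Homo sapiens as the target (a lower number here means a stronger inhibitor, a higher number a weaker inhibitor), compound 1 returns only a limit, > 48000 nM, and not a number. Two further members of the set behave in the same way. Compound 2 `CCCc1nc(C)c2cnn(CC(=O)OCC)c(=O)n12` in this assay likewise gives only a limit, > 48000 nM. Compound 3 `COCc1ncc2cnnc(S)n12` also stops at a limit in this assay, > 48000 nM. Among the measured compounds shown here, every value so far therefore sits at the limit of > 48000 nM in this assay, at which 3 of the 3 values shown sit. For the measured compounds named here, no measured step between two compounds exists, so nothing in the data shows how far any single change moves the read-out within this set.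

Compound 4 `CSc1nncc2c(C)ncn12` is the next to be tested. It differs from compound 1 in one place: methylsulfanyl in place of methylamino on an aromatic carbon. Beyond what is counted in that change, the present data say nothing about its effect.

With all measured values at a limit and no step beyond the scatter on record, no step beyond the scatter is expected in either direction, and the most likely outcome is that compound 4 also stops at the limit of this assay. The estimate for compound 4 in this assay is 60000 nM, with a range from 20000 nM to 200000 nM. The step this estimate means, a step that the limit leaves unreadable from compound 1 to compound 4, is expected to be none beyond the scatter.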

Compound 4, half-maximal inhibitory concentration: > 48000 nM
Compound 4: a limit, no number; the forecaster's own chance of this, stated with the estimate: 80%; the middle value does not contradict the limit.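

In this assay, among the compounds shown here, compound 4 returns only a limit, > 48000 nM, and not a number, so no step from compound 1 to compound 4 can be read. The set now stands as follows: the limit of > 48000 nM in this assay, at which 4 of the 4 values shown sit. The compounds shown leave open whether any change to the shared core gives a measurable value in this assay.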